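The compounds below may be only part of what the source reports. "The series", "measured", "known", "first", "only" and "open" are said of these compounds alone.

Compound 1 `COc1ccc(-c2cc(-c3cc(OC)c(OC)c(OC)c3)nc(N)n2)cc1` is one of two compounds tested in an ADME assay on THP-1 cells (Homo sapiens) for cytotoxicity, read by MTT assay; a higher number here means that more compound is tolerated, a lower number that less compound is tolerated. In this assay compound 1 gives 100000 nM, while compound 2 `COc1ccc(C2=NN(C(C)=O)C(c3cc(OC)c(OC)c(OC)c3)C2)cc1` gives 200000 nM, and the two values lie within the scatter of each other. Compound 3 `COc1cc(-c2cc(-c3ccc(Br)cc3)nc(N)n2)cc(OC)c1OC` differs from compound 1 by bromo in place of methoxy on an aromatic carbon. Among the compounds with values here, no measured pair carries this change, so the step is expected to stay within the scatter, at no change at the digits printed from compound 1 to compound 3 (within the scatter). For compound 3 the estimate in this assay is 100000 nM, with a range from 35000 nM to 250000 nM.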

Compound 3, half-maximal cytotoxic concentration: 100000 nM
The estimate for compound 3 equals the measured number at the digits printed, within the range that was stated.
By their numbers in this assay, from the lowest: compounds 1, 3 and 2 (each within the scatter of the next).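

Within the data shown here, replacing 4-methoxyphenyl with 4-bromophenyl gives the first comparison in this assay between compounds that differ in one place, and it reads no change at the digits printed from compound 1 to compound 3 (within the scatter) on the shared core. At this aromatic carbon, then, bromo and methoxy cannot be told apart in this assay. No available evidence offers a reason for this result.

From the compounds shown here alone, whether an amine or a carboxylic acid at this carbon would also stay within the scatter remains open. So does whether the same exchange would read alike on the core of compound 2.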